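Bigger Amine on a Highly Protein-Bound Series

A few compounds are considered here, and "the series" means these few. Any claim that something is new, unique, unknown or untested is made for them only; others in the source may bear on it.

Measured so far in an ADME assay on a cell-free system (plasma, Homo sapiens) for protein binding:
Compound 1 (`CNc1nccc(N2CC[C@H](NC(=O)Nc3ccc(CN(C)C)c(C(F)(F)F)c3)C2)n1`): 94.3%
Compound 2 (`O=C(Nc1ccc(Cl)c(C(F)(F)F)c1)N[C@H]1CCN(c2ccnc(NC3CC3)n2)C1`): > 99.9% (a limit of the assay, not a number)

Going by the values given here, compound 1 stands at 94.3%, and this is the only true number available so far. Compound 2 sits at the limit of the assay (the limit of > 99.9% in this assay, at which 1 of the 2 values shown sits). The two compounds differ in more than one place, so together they do not show what a single change does.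

Compound 3 (`CCN1CCN(Cc2ccc(NC(=O)N[C@H]3CCN(c4ccnc(NC)n4)C3)cc2C(F)(F)F)CC1`) keeps the rest of compound 1 and carries 4-ethylpiperazin-1-yl in place of dimethylamino on a saturated chain carbon bound to an aromatic carbon. Among the compounds with values here, no measured step resembles this change, so the expectation rests on compound 1 alone. A small upward move is expected in this assay, with the larger group giving the estimated step a 1.4-fold lower unbound fraction from compound 1 to compound 3 (0.15 log units; within the scatter), and that move may well stay within the usual scatter. The estimate for compound 3 is 96% (expected range 91% to 98.8%).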

Compound 3, plasma protein binding: 75.2%
For compound 3 the middle estimate is 6.2-fold (0.79 log units) (unbound fraction) below the measured one, and the stated range ends above it.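

In this assay, going by these compounds alone, this is the first change that can be read on its own, and it gives a 4.4-fold higher unbound fraction from compound 1 to compound 3 (0.64 log units; beyond the scatter). At this saturated chain carbon bound to an aromatic carbon, 4-ethylpiperazin-1-yl is the larger group, with its six-membered non-aromatic ring, yet in this one pair the swap from dimethylamino leaves more of the compound free, not less, so added size alone does not push the binding up here. Within the data shown here, nothing measured so far accounts for the direction of this step.

Among these compounds, the single step leaves open which part of the new group matters, as the ring, the second ring nitrogen and the ethyl group all enter together. On these data alone, a piperazine ring with no ethyl group on it, or a morpholine ring at the same place, would help to pull these parts apart, and whether any such shift carries over to other parts of the series also remains open.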